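Cytotoxicity of a diaryl ether series in human fibroblasts

This account rests on a few compounds, and the source may have more. Where it says the series, first, only, none or still open, it means among the compounds named here.

The study covers four compounds that share one core and differ only in the aryl group carried on the ether oxygen. Compound 1 `Cc1cn(C2CCN(Cc3cccc(Oc4cc(C(F)(F)F)cc(C(F)(F)F)c4)c3)CC2)c(=O)[nH]c1=O` appears in an ADME assay on MRC5 cells (Homo sapiens) for cytotoxicity, read by fluorescence and resazurin assay, with a stated time of 3 days (on this read-out higher numbers stand for weaker inhibition and lower numbers for stronger inhibition), with the entry "not determined" (no result reported), and compound 3 `Cc1cn(C2CCN(Cc3cc(Oc4cc(Cl)cc(Cl)c4)ccn3)CC2)c(=O)[nH]c1=O` appears in this assay with the entry "not determined" (no result reported); for both of them no number was reported. Compound 2 `Cc1cn(C2CCN(Cc3cccc(Oc4cccc(OC(F)(F)F)c4)c3)CC2)c(=O)[nH]c1=O` is therefore the only member with a measured value: in this assay compound 2 gives 5260 nM, and it stands alone, with nothing to compare it against on the numbers shown.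

Compound 4 `Cc1cn(C2CCN(Cc3cccc(Oc4cc(Cl)cc(Cl)c4)c3)CC2)c(=O)[nH]c1=O` is the compound still to be measured. Its difference from compound 2 is 3,5-dichlorophenyl in place of 3-(trifluoromethoxy)phenyl on an oxygen on an aromatic ring. For the measured compounds named here, since no pair of measured compounds differs in a single place, there is no measured step from which the size of this change could be read off.

What can be expected rests on compound 2 alone. With only the value 5260 nM of compound 2 to go on, a step from compound 2 to compound 4 that stays within the usual scatter, or at most modestly in the direction of stronger inhibition, is expected, that is a 1.3-fold lower number from compound 2 to compound 4 (0.12 log units; within the scatter). On that basis compound 4 is estimated to give 4000 nM in this assay, within a range of 1500 nM to 12000 nM.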

Compound 4, half-maximal inhibitory concentration: 6730 nM
For compound 4 the middle estimate is 1.7-fold (0.23 log units) below the measured one; low and high end bracket the measured number.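

For the compounds shown here, the step gives the first reading of a change at this position, on an oxygen on an aromatic ring: in this assay the result is a 1.3-fold higher number from compound 2 to compound 4 (0.11 log units; within the scatter), so the two compounds are not separated on this read-out. The exchange of 3-(trifluoromethoxy)phenyl for 3,5-dichlorophenyl replaces a group holding oxygen and fluorine with one holding chlorine and fewer heavy atoms, and this single pair shows that such a change in the aryl group need not move the number beyond the scatter, though one pair establishes no rule for the series. Nothing at hand ties this result to any property of either group.

On these data alone, compound 1 and compound 3 carry no number, so the steps that involve them cannot be read, and the effect of the other aryl groups remains unknown. Also open, as far as these compounds go, is whether an aryl group bearing an amine or a carboxylic acid on the same oxygen would give a number beyond the scatter of these two compounds.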